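One More Chain Carbon at the Limit

A few compounds are considered here, and "the series" means these few. Any claim that something is new, unique, unknown or untested is made for them only; others in the source may bear on it.

Values in an ADME assay on HL-60 cells (Homo sapiens) for cytotoxicity, read by resazurin assay, with a stated time of 72 h (a lower number here means that less compound is needed, a higher number that more compound is needed for the effect), all of them limits:

Compound 1 `O=C(NCCCCO)Nc1nc2ccc(C(=O)c3ccccc3)cc2[nH]1` gives > 30000 nM
Compound 2 `NCCCC(=O)Nc1nc2ccc(C(=O)c3ccccc3)cc2[nH]1` gives > 30000 nM
Compound 3 `O=C(CCC1CCNCC1)Nc1nc2ccc(C(=O)c3ccccc3)cc2[nH]1` gives > 30000 nM

Compound 3 gives only a limit, > 30000 nM, and no number. This places it at the limit of > 30000 nM in this assay, at which 3 of the 3 values shown sit, so nothing ranks it against compound 1 or compound 2.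

The unmeasured compound 4 `O=C(CCCC1CCNCC1)Nc1nc2ccc(C(=O)c3ccccc3)cc2[nH]1` differs from compound 3 by (piperidin-4-yl)methyl in place of piperidin-4-yl on a saturated chain carbon, two bonds along the chain from a carbonyl carbon, which, cut one bond further out, reads 2-(piperidin-4-yl)ethyl to 3-(piperidin-4-yl)propyl.

The closest measured change is a step that the two limits leave unreadable from compound 2 to compound 3, which alters a group at the same place on the chain. The two others are a step that the two limits leave unreadable from compound 1 to compound 2 and a step that the two limits leave unreadable from compound 1 to compound 3, and both replace the (4-hydroxybutyl)amino group on a carbonyl carbon. None of these steps has a readable size or direction, so the expectation rests on the shared limit alone.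

The expected result is a number no higher from compound 3 to compound 4 (the limit leaves the size open), with no direction expected beyond the scatter. Compound 4 is estimated at 30000 nM, with an expected range from 10000 nM to 60000 nM. A report of only a limit is the likeliest outcome.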

Compound 4, half-maximal effective concentration: > 30000 nM
Compound 4 was reported as a limit (the forecaster's own chance of this, stated with the estimate: 80%); the middle value lies on the limit itself.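

In this assay compound 4 gives > 30000 nM, which is a limit and not a number. No step to compound 4 from compound 1, compound 2 or compound 3 can be read, and all four compounds share one position: the limit of > 30000 nM in this assay, at which 4 of the 4 values shown sit.

The compounds shown leave open how these four would rank in this assay.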